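Chloro added to the triazole phenyl of compound 2

A few compounds are considered here, and "the series" means these few. Any claim that something is new, unique, unknown or untested is made for them only; others in the source may bear on it.

For the measured compounds named here, compound 1 `O=c1[nH]cc(S(=O)(=O)Nc2ccccc2-c2cn(-c3cccc(Cl)c3)nn2)c(=O)[nH]1` is the only member of this pair with a number: in a functional assay on OVCAR-3 cells (Homo sapiens) for antiproliferative activity, read by MTT assay, with a stated time of 24 h (on this read-out higher numbers stand for weaker inhibition and lower numbers for stronger inhibition), compound 1 gives 2180 nM. Compound 2 `O=c1[nH]cc(S(=O)(=O)Nc2cccc(-c3cn(-c4ccccc4)nn3)c2)c(=O)[nH]1` keeps the shared core but carries an unsubstituted phenyl on the triazole and a different attachment of the triazole to the aniline ring. In this assay compound 2 returns only a limit, > 20000 nM, not a measured number; it stands at the limit of > 20000 nM in this assay, at which 1 of the 2 values shown sits. Going by the values given here, no step between compound 1 and compound 2 is computed, and their two values show only that one is resolved and the other is not.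

Compound 3 `O=c1[nH]cc(S(=O)(=O)Nc2cccc(-c3cn(-c4ccc(Cl)cc4)nn3)c2)c(=O)[nH]1` remains to be measured. It differs from compound 2 by chloro in place of hydrogen on an aromatic carbon. Among the compounds with values here, no measured step covers that change, so the direction must be guessed: the expected step from compound 2 to compound 3 is an at least 1.3-fold lower number from compound 2 to compound 3 (0.12 log units; that floor lies within the scatter), at most a modest gain and possibly none beyond the scatter, with a real chance that compound 3 also stops at a limit. Compound 3 is therefore estimated at 15000 nM, expected to lie between 4000 nM and 40000 nM.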

Compound 3, half-maximal inhibitory concentration: 2040 nM
The estimate for compound 3 lay 7.4-fold (0.87 log units) above the measured number; measured number outside the range, below it.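

In this assay, for the compounds shown here, the change from phenyl to 4-chlorophenyl gives an at least 9.8-fold lower number from compound 2 to compound 3 (0.99 log units; beyond the scatter), the first step that can be read at this position. A single chlorine atom, placed on an aromatic carbon para to a large group, is enough to bring the triazole attachment of compound 2 from a limit to a resolved value, so this ring position is not indifferent to substitution. Compound 2 stands only at a limit, not a number, so the step is a floor and its true size remains unknown: the limit of > 20000 nM in this assay, at which 1 of the 3 values shown sits.

The compounds shown leave open whether this step is specific to chloro or would also follow from fluoro, methyl, methoxy or an amine at the same place on the ring. Also open, as far as these compounds go, is whether the same change from phenyl to 4-chlorophenyl would give a step of similar size with the triazole attachment of compound 1.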